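Methoxy removal on the benzyl arm of the core

A few compounds are considered here, and "the series" means these few. Any claim that something is new, unique, unknown or untested is made for them only; others in the source may bear on it.

Compound 3 `COc1ccc(Cc2cnc(CCc3ccc(-c4ccccc4C(=O)O)cc3)[nH]2)cc1` gives 5360 nM in an in vitro functional assay on cells for agonist activity at Bombesin receptor subtype-3 (Homo sapiens), read by luminescence and calcium flux (a higher number here means that more compound is needed for the effect, a lower number that less compound is needed), and so stands highest of the three numbers measured. Compound 1 `O=C(O)c1ccccc1-c1ccc(CCc2ncc(CC3CCCCC3)[nH]2)cc1` gives 41 nM and compound 2 `CC(C)(C)CCc1cnc(CCc2ccc(-c3ccccc3C(=O)O)cc2)[nH]1` gives 39 nM in this assay; between these two the step is a 1.1-fold lower number from compound 1 to compound 2 (0.02 log units; within the scatter), so the cyclohexyl and neopentyl arms cannot be told apart. The aryl arm sets compound 3 apart: a 130-fold higher number from compound 1 to compound 3 (2.12 log units; beyond the scatter) and a 140-fold higher number from compound 2 to compound 3 (2.14 log units; beyond the scatter).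

Compound 4 `O=C(O)c1ccccc1-c1ccc(CCc2ncc(Cc3ccccc3)[nH]2)cc1` differs from compound 3 only in one place: hydrogen in place of methoxy on an aromatic carbon. Among the measured compounds shown here, no measured step bears directly on a methoxy group on this arm; the only steps available swap the whole arm, and they say that an aromatic arm of this kind, whether or not a methoxy is present, is a poor substitute for cyclohexyl or neopentyl. Compound 4 keeps the aromatic arm, so the expectation for compound 4 is a number close to that of compound 3, with a modest move in either direction allowed for want of any direct comparison, and compound 4 is therefore estimated at a 1.5-fold lower number from compound 3 to compound 4 (0.19 log units; within the scatter) in this assay.

Compound 4 is expected to give 3500 nM in this assay, within a range of 900 nM to 14000 nM.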

Compound 4, half-maximal effective concentration: 205 nM
For compound 4 the middle estimate is 17-fold (1.23 log units) above the measured one, outside the stated range (below it).
By their numbers in this assay, from the lowest: compounds 2 and 1 (each within the scatter of the next); then compound 4; then compound 3.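

The methoxy alone accounts for most of the penalty on this arm in this assay (a 26-fold lower number from compound 3 to compound 4 (1.42 log units; beyond the scatter)), so the large steps seen earlier for compound 3 cannot be read as a penalty for any aromatic arm. An aromatic arm is still not equal to the saturated arms, since the benzyl arm of compound 4 remains beyond the scatter from both the neopentyl arm (a 5.3-fold higher number from compound 2 to compound 4 (0.72 log units; beyond the scatter)) and the cyclohexyl arm (a 5.0-fold higher number from compound 1 to compound 4 (0.70 log units; beyond the scatter)), and these two steps are modest where those to compound 3 are large. The aromatic carbon that carries the methoxy in compound 3 is thus a sensitive point on the series, with hydrogen there recovering much of the number but not all of it.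

As far as these compounds go, whether a fluorine, a methyl or a hydroxyl on that same aromatic carbon would follow hydrogen or methoxy remains open, as does the effect of a methoxy on another carbon of the ring. Nothing on hand gives a reason for the size of the methoxy step, or for the remaining gap to the saturated arms.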